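From 3,5-dimethylphenyl to 4-methylphenyl on compound 2

The compounds below may be only part of what the source reports. "The series", "measured", "known", "first", "only" and "open" are said of these compounds alone.

In a functional assay on NB1 cells (Homo sapiens) for antiproliferative activity, with a stated time of 72 h (on this read-out lower numbers stand for stronger inhibition and higher numbers for weaker inhibition), compound 1 `Cc1ccc(NC(=O)CCN(Cc2ccc(C(=O)NO)cc2)C(=O)c2cc(C)cc(C)c2)cc1` gives 670 nM, while compound 2 `Cc1cc(C)cc(C(=O)N(CCC(=O)NCc2ccccc2)Cc2ccc(C(=O)NO)cc2)c1` gives 3870 nM, the higher and therefore weaker of the two numbers. Compound 3 `Cc1ccc(C(=O)N(CCC(=O)NCc2ccccc2)Cc2ccc(C(=O)NO)cc2)cc1` has not yet been measured. It differs from compound 2 on a carbonyl carbon, with 4-methylphenyl in place of 3,5-dimethylphenyl on a carbonyl carbon. Within the data shown here, only one measured step is available, a 5.8-fold higher number from compound 1 to compound 2 (0.76 log units; beyond the scatter), and it comes from benzyl in place of 4-methylphenyl on an amide-type nitrogen. Among the measured compounds shown here, that change lies elsewhere in the molecule, so it offers no direct guide here, and no measured pair shows this exchange on the carbonyl carbon. The expected change in this assay therefore stays within the usual scatter, with no firm direction. The estimated step is a 1.2-fold lower number from compound 2 to compound 3 (0.07 log units; within the scatter). For compound 3, the expected value is 3300 nM, with an estimated range of 1400 nM to 8000 nM.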

Compound 3, half-maximal inhibitory concentration: 1610 nM
Beside the measured number, compound 3's estimate is 2.0-fold (0.31 log units) above it, within the range that was stated.
By their numbers in this assay, from the lowest: compound 1; then compound 3; then compound 2.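

Among these compounds, this is the first measured change at the aromatic group on the carbonyl carbon, and it shows that this part of the molecule also affects activity in this assay: replacing 3,5-dimethylphenyl with 4-methylphenyl gives a 2.4-fold lower number from compound 2 to compound 3 (0.38 log units; beyond the scatter). Among the compounds shown here, until now, the only measured step, a 5.8-fold higher number from compound 1 to compound 2 (0.76 log units; beyond the scatter), came from a change on the amide-type nitrogen, so two separate places are now known to shift the number. Nothing available explains why this exchange moves the number in this direction.

The exchange changes both the number of methyl groups and where they sit, so this one step cannot separate those two changes. A 3-methylphenyl or an unsubstituted phenyl on the same carbonyl carbon would help to tell them apart.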